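Trimming the side chain of compound 3: a forecast

A few compounds are considered here, and "the series" means these few. Any claim that something is new, unique, unknown or untested is made for them only; others in the source may bear on it.

Compound 1, `Cc1c(O)cc(CCCCC(C)[C@H](C)O)oc1=O`, in a functional assay on HCT-116 cells (Homo sapiens) for cytotoxicity, read by MTT assay; a higher number here means a weaker inhibitor, a lower number a stronger inhibitor: > 200000 nM, a limit of the assay.
Compound 2, `Cc1c(O)cc(CCCCC(C)(C)O)oc1=O`, in this assay: > 200000 nM, a limit of the assay.
Compound 3, `Cc1c(O)cc(CCCCC(C)C)oc1=O`, in this assay: > 200000 nM, a limit of the assay.

Compound 3 stands where every measured compound stands, at the limit of > 200000 nM in this assay, at which 3 of the 3 values shown sit; no number has been read for any of the three. The three steps among them, a step that the two limits leave unreadable from compound 1 to compound 2, a step that the two limits leave unreadable from compound 1 to compound 3 and a step that the two limits leave unreadable from compound 2 to compound 3, are therefore unreadable in size and direction, since each joins two limits.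

Compound 4, `Cc1c(O)cc(CCCC(C)C)oc1=O`, differs from compound 3 in one place: isopropyl in place of isobutyl on a saturated chain carbon, three bonds along the chain from an aromatic carbon. Going by the values given here, no measured step touches this position, and the steps that exist cannot tell how large a change on the chain can be before the read-out moves. With the whole measured set at the limit, compound 4 is expected to remain there as well, so that the step that the limit leaves unreadable from compound 3 to compound 4 is estimated as no readable movement. The estimate for compound 4 in this assay is 300000 nM, with a range from 100000 nM to 1000000 nM, most likely reported only as a limit.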

Compound 4, half-maximal inhibitory concentration: > 200000 nM
Compound 4: only a limit was reported; the forecaster's own chance of this, stated with the estimate: 85%; the middle value lies beyond the limit too.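

In this assay compound 4 gives > 200000 nM as a limit of the assay. Going by these compounds alone, no step from compound 1, compound 2 or compound 3 to compound 4 can be read, since each joins two limits: the limit of > 200000 nM in this assay, at which 4 of the 4 values shown sit. The compounds shown leave open whether any side chain on the shared core gives a readable value in this assay at all.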